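The compounds below may be only part of what the source reports. "The series", "measured", "known", "first", "only" and "open" are said of these compounds alone.

Measured so far in a functional assay on HCT-116 cells (Homo sapiens) for antiproliferative activity, read by MTT assay, with a stated time of 72 h; on this read-out lower numbers stand for stronger inhibition and higher numbers for weaker inhibition:

Compound 1 `O=C1O[C@H]([C@@H](O)Cn2cc(-c3cc(C(F)(F)F)cc(C(F)(F)F)c3)nn2)C(OCc2ccccc2)=C1OCc1ccccc1` gives 57200 nM.
Compound 2 `COc1ccccc1-c1cn(C[C@H](O)[C@H]2OC(=O)C(OCc3ccccc3)=C2OCc2ccccc2)nn1` gives only a limit of the assay, > 100000 nM.
Compound 3 `O=C1O/C(=C\Cn2cc(-c3cccc(O)c3)nn2)C(OCc2ccccc2)=C1OCc1ccccc1` gives 63600 nM.

Compound 2 thus stands apart on these numbers: it has no measured value of its own, only the limit (the limit of > 100000 nM in this assay, at which 1 of the 3 values shown sits), so nothing can be said about how far beyond that limit it lies. Compounds 1 and 3, which share the same core, are both weak in this assay.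

Compound 4 `O=C1O[C@H]([C@@H](O)Cn2cc(CCO)nn2)C(OCc2ccccc2)=C1OCc1ccccc1` is compound 2 with one change: 2-hydroxyethyl in place of 2-methoxyphenyl on an aromatic carbon. The 2-methoxyphenyl that leaves is replaced by a much smaller 2-hydroxyethyl on the aromatic carbon.

Going by the values given here, no pair of measured compounds differing in one place is available to show what such a change does. Given that compound 2 reaches only a limit and compounds 1 and 3 are themselves weak, the expected step in this assay an at least 1.1-fold lower number from compound 2 to compound 4 (0.04 log units; that floor lies within the scatter) is small and uncertain in direction, possibly none beyond the scatter. Compound 4 is therefore expected to come out near 90000 nM, within a range of 30000 nM to 300000 nM, with a fair chance that only a limit is reported again.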

Compound 4, half-maximal inhibitory concentration: 72700 nM
The estimate for compound 4 lay 1.2-fold (0.09 log units) above the measured number; low and high end bracket the measured number.
By their numbers in this assay, from the lowest: compounds 1, 3 and 4 (each within the scatter of the next). At a limit, above all of these: compound 2.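

In this assay, compound 2 gives > 100000 nM, which is a limit of the assay and not a number. The step therefore has only a floor, an at least 1.3-fold lower number from compound 2 to compound 4 (0.13 log units; that floor lies within the scatter), and that floor lies within the scatter, so it does not establish a real gain from this change. Going by these compounds alone, what is new is that a group with no ring on this aromatic carbon still gives a measured value: the earlier compounds all carry a six-membered aromatic ring here, yet compound 4 lies within the scatter of compound 1.

On these data alone, it remains open whether the hydroxyl of the 2-hydroxyethyl matters, which a plain ethyl group at this place would test. Also open, as far as these compounds go, is how an amine, a carboxylic acid or a longer chain ending in hydroxyl would read out here.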